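The source may hold more compounds than are shown below. What is called first, only, known or untested is meant among the compounds shown, and "the series" means these compounds.

Measured compounds in a functional assay on HepG2 cells (Homo sapiens) for antiproliferative activity, read by MTT assay, with a stated time of 48 h; a higher number here means a weaker inhibitor, a lower number a stronger inhibitor:
compound 1, `COc1ccc(/C=C/C(=O)Nc2cc3c(Nc4ccc(Cl)c(Cl)c4)ncnc3s2)cc1`, gives 30600 nM
compound 2, `COc1ccc(/C=C/C(=O)Nc2cc3c(Nc4cc(Cl)cc(Cl)c4)ncnc3s2)cc1`, gives 41800 nM
compound 3, `O=C(/C=C/c1ccccc1)Nc1cc2ncnc(Nc3cc(Cl)cc(Cl)c3)c2s1`, gives 10700 nM

Compound 3 gives the lowest number of the three, and its steps to compound 1 and to compound 2 both lie beyond the scatter, so it is the strongest inhibitor measured here. Compound 1 and compound 2 share a core that is not that of compound 3; the difference between the two cores is not broken down here. Compound 1 and compound 2 differ in one place: 3,4-dichlorophenyl in place of 3,5-dichlorophenyl on a nitrogen on an aromatic ring. That change gave a 1.4-fold lower number from compound 2 to compound 1 (0.14 log units; within the scatter).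

Compound 4, `O=C(/C=C/c1ccccc1)Nc1cc2ncnc(Nc3ccc(Cl)c(Cl)c3)c2s1`, is not yet measured. It stands to compound 3 as compound 1 stands to compound 2: 3,4-dichlorophenyl in place of 3,5-dichlorophenyl on a nitrogen on an aromatic ring. The place is the same in both pairs, so this is the same change on the other core. In this assay the step expected here is a 1.3-fold lower number from compound 3 to compound 4 (0.10 log units; within the scatter), set beside the earlier one, because a 1.4-fold lower number from compound 2 to compound 1 (0.14 log units; within the scatter) lay within the scatter. Compound 4 is therefore expected to give about 8500 nM. The estimate for compound 4 is taken to fall between 4000 nM and 18000 nM.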

Compound 4, half-maximal inhibitory concentration: 13400 nM
For compound 4 the middle estimate is 1.6-fold (0.20 log units) below the measured one; low and high end bracket the measured number.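

In this assay 3,4-dichlorophenyl in place of 3,5-dichlorophenyl on the core of compound 3 gives a 1.3-fold higher number from compound 3 to compound 4 (0.10 log units; within the scatter) and so does not separate the two groups on this core. This does not show that the change is without any effect: in these two pairs, in this one assay, any effect stays too small to read, and the two steps cannot be given a shared direction. Carried from one core to the other, the change stays within the scatter on both, and the two steps do not differ: the same change on two cores in this assay, a 1.4-fold lower number (0.14 log units; within the scatter) from compound 2 to compound 1 and a 1.3-fold higher number (0.10 log units; within the scatter) from compound 3 to compound 4, 1.7-fold (0.23 log units) apart, within the scatter of two such steps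

The two cores differ in more than one place, so these pairs do not tell which part of them sets the general level of the numbers. Also open, as far as these compounds go, is what other groups on that nitrogen would give, such as a phenyl ring carrying a single chlorine, a phenyl ring carrying an amine or a carboxylic acid, or a longer chain between the nitrogen and the ring.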